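Furan-2-carboxamide analogue in the pyrazolopyrimidine urea/amide series

The source may hold more compounds than are shown below. What is called first, only, known or untested is meant among the compounds shown, and "the series" means these compounds.

Measured so far in an assay on CHO cells for displacement of a labelled ligand from adenosine receptor A1 (Homo sapiens), read by scintillation counting, with a stated time of 120 min, tested at 1 uM; a lower number here means less inhibition, a higher number more inhibition at the concentration tested (going by the name of the read-out):
- compound 1, `Cc1nc(NC(=O)NCc2ccccc2)c2nn(-c3ccccc3)cc2n1`: 26%
- compound 2, `CC(=O)Nc1nc(C)nc2cn(-c3ccccc3)nc12`: 25%
- compound 3, `Cc1nc(NC(=O)Nc2ccccc2)c2nn(-c3ccccc3)cc2n1`: 1%

Compound 3 stands lowest of the three. Its nearest neighbour is compound 2, and the gap a number 24 percentage points lower from compound 2 to compound 3 (beyond the scatter) lies beyond the scatter; the gap a number 25 percentage points lower from compound 1 to compound 3 (beyond the scatter) is of much the same size. Compounds 1 and 2 themselves differ only by a number 1 percentage points lower from compound 1 to compound 2 (within the scatter), which is within the scatter, so the benzylurea and the acetamide cannot be told apart on these numbers.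

Compound 4, `Cc1nc(NC(=O)c2ccco2)c2nn(-c3ccccc3)cc2n1`, is the next step from compound 3: furan-2-yl in place of anilino on a carbonyl carbon. Among the measured compounds shown here, no measured pair shows this exact exchange. The two steps that bear on it are those leading into compound 3: anilino in place of methyl on the carbonyl carbon cost a number 24 percentage points lower from compound 2 to compound 3 (beyond the scatter), and phenyl in place of benzyl on the amide-type nitrogen cost a number 25 percentage points lower from compound 1 to compound 3 (beyond the scatter). Compound 4 removes the anilino group again and carries an aromatic acyl group on the carbonyl carbon, so the closest measured reference is the amide compound 2 rather than compound 3.

In this assay compound 4 is therefore expected to recover part of the loss, with an estimated step of a number 19 percentage points higher from compound 3 to compound 4 (beyond the scatter) upward. The estimated value for compound 4 is 20%, with a range from 5% to 40%.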

Compound 4, a percentage reported as inhibition, at one concentration (the size of the read-out at that concentration, not a potency): 20%
For compound 4 middle estimate and measured number coincide at the digits printed; the measured number falls inside the stated range.
By their numbers in this assay, from the lowest: compound 3; then compounds 4, 2 and 1 (each within the scatter of the next).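

In this assay, the low number of compound 3 does not extend to every aromatic group on this carbonyl carbon: furan-2-yl in place of anilino gives a number 19 percentage points higher from compound 3 to compound 4 (beyond the scatter), and compound 4 cannot be told apart from the acetamide or the benzylurea, with a number 5 percentage points lower from compound 2 to compound 4 (within the scatter) and a number 6 percentage points lower from compound 1 to compound 4 (within the scatter), both within the scatter. Among the compounds shown, the anilino group of compound 3 alone goes with the low number, while methyl, benzylamino and furan-2-yl on this carbon give numbers that cannot be separated, so the number stays level across these three quite different groups. The exchange alters ring size, the hetero atom and the hydrogen-bond donor and acceptor counts all at once, and no measurement available here accounts for the step or assigns it to any one of these differences.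

On these data alone, whether the furan oxygen matters stays open: a plain phenyl ring or a thiophene ring on the same carbonyl carbon would separate it from ring size. A saturated ring such as cyclohexyl would show whether an aromatic group is needed at all, and with a single tested concentration, none of these numbers gives a potency.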